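The source may report more compounds than this note shows. Statements on the series, on what has been measured and on what is new or still open speak of the compounds shown alone.

The series shares the core of compound 1 `COc1ccc(-c2cc3ccccc3nc2/C=C/C(=O)c2ccc(F)cc2)cc1` and varies only the aryl group on the carbonyl carbon. In a functional assay on H184B5F5/M10 cells (Homo sapiens) for antiproliferative activity, read by XTT assay, with a stated time of 72 h (a higher number here means a weaker inhibitor, a lower number a stronger inhibitor), compound 1 gives > 10000 nM, which is a limit of this assay and not a number. Compound 2 `COc1ccc(-c2cc3ccccc3nc2/C=C/C(=O)c2ccc(OC)cc2OC)cc1` gives 6110 nM in this assay. Compound 3 `COc1ccc(-c2cc3ccccc3nc2/C=C/C(=O)c2ccc(OC)c(OC)c2)cc1` gives 7240 nM in this assay; it stands at the top of the two numbers shown, with compound 2 nearest and within the scatter of it. The step of an at least 1.6-fold lower number from compound 1 to compound 2 (0.21 log units; that floor lies within the scatter) and the step of an at least 1.3-fold lower number from compound 1 to compound 3 (0.14 log units; that floor lies within the scatter) both begin at the limit (the limit of > 10000 nM in this assay, at which 1 of the 3 values shown sits), so only floors are known and both floors lie within the scatter; the step of a 1.2-fold higher number from compound 2 to compound 3 (0.07 log units; within the scatter) is within the scatter as well. Compound 4 `COc1ccc(-c2cc3ccccc3nc2/C=C/C(=O)c2ccco2)cc1` carries furan-2-yl in place of 3,4-dimethoxyphenyl on a carbonyl carbon. For the measured compounds named here, no measured step touches a furan-2-yl group itself; the three steps that exchange the aryl group on the carbonyl carbon were all small, so a small step in this assay with no set direction is expected from the present change. The expected step is a 1.0-fold higher number from compound 3 to compound 4 (0.02 log units; within the scatter). Compound 4 is thus expected at about 7500 nM in this assay, with a range from 3000 nM to 20000 nM, and a fair chance that only a limit is reported.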

Compound 4, half-maximal inhibitory concentration: 6240 nM
Estimate against measurement, compound 4: 1.2-fold (0.08 log units) above; the range from low to high includes it.
By their numbers in this assay, from the lowest: compounds 2, 4 and 3 (each within the scatter of the next). At a limit, above all of these: compound 1.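

In this assay, furan-2-yl on the carbonyl carbon brings a five-membered aromatic ring with 1 hetero atom and 5 heavy atoms in place of a six-membered aromatic ring of carbon only, and the number does not separate from those of the dimethoxyphenyl compounds: a 1.2-fold lower number from compound 3 to compound 4 (0.06 log units; within the scatter) and a 1.0-fold higher number from compound 2 to compound 4 (0.01 log units; within the scatter). Until now every group at this place was a substituted six-membered ring of carbon only, so compound 4 adds that neither such a ring nor its methoxy groups are required for a value in this range in this assay. Against the 4-fluorophenyl compound only a floor exists, an at least 1.6-fold lower number from compound 1 to compound 4 (0.20 log units; that floor lies within the scatter), so whether that compound truly differs from compound 4 cannot be read, as its value is a limit: the limit of > 10000 nM in this assay, at which 1 of the 4 values shown sits.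

On these data alone, compounds 2, 3 and 4 all lie within the scatter of one another, so it remains open whether any group at this place can move the number beyond it. Nothing here tells how a saturated ring such as cyclohexyl, a short chain such as methyl, or a phenyl ring carrying an amine or a carboxylic acid would behave.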